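Pyrrolidinyl to Piperidinyl Exchange in an Inactive Series

This account rests on a few compounds, and the source may have more. Where it says the series, first, only, none or still open, it means among the compounds named here.

Compound 1 `O=C(CN1CCCC1)Nc1ccc2ncnc(Nc3ccc(Br)cc3)c2c1`: > 100000 nM
Compound 2 `O=C(CN1CCCCC1)Nc1ccc2ncnc(Nc3ccc(Br)cc3)c2c1`: > 100000 nM
Compound 3 `O=C(CN1CCCC1)Nc1ccc2ncnc(Nc3ccc(Cl)c(C(F)(F)F)c3)c2c1`: > 100000 nM

In a functional assay on MCF7 cells (Homo sapiens) for antiproliferative activity, read by MTT assay, with a stated time of 48 h (on this read-out lower numbers stand for stronger inhibition and higher numbers for weaker inhibition), compound 1 gives > 100000 nM, which is a limit of the assay and not a number. Compound 2 likewise gives > 100000 nM in this assay, again a limit. Compound 3 gives > 100000 nM in this assay, also a limit. Compound 2 is related to compound 1 by piperidin-1-yl in place of pyrrolidin-1-yl on a saturated chain carbon bound to a carbonyl carbon, and this step reads a step that the two limits leave unreadable from compound 1 to compound 2. Compound 1 and compound 3 carry different cores, but the difference between the two cores is not broken down here.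

Compound 4 `O=C(CN1CCCCC1)Nc1ccc2ncnc(Nc3ccc(Cl)c(C(F)(F)F)c3)c2c1` has not yet been measured. Among the compounds with values here, it differs from compound 3 by piperidin-1-yl in place of pyrrolidin-1-yl on a saturated chain carbon bound to a carbonyl carbon, which is the same change as the one from compound 1 to compound 2, at the same place. Within the data shown here, that change occurs twice among the four compounds, and the one measured instance of it could not be read because both ends sit at a limit.

Because the limit of > 100000 nM in this assay, at which 3 of the 3 values shown sit, holds every value shown so far, compound 4 is expected to sit at the same limit. Compound 4 is expected to give about 100000 nM in this assay, with a range from 40000 nM to 300000 nM. This estimate means an expected step of a number no higher from compound 3 to compound 4 (the limit leaves the size open), resting on the step from compound 1 to compound 2 being unreadable and on compound 3 itself standing at the limit.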

Compound 4, half-maximal inhibitory concentration: > 100000 nM
Compound 4 gave a limit, no number; the forecaster's own chance of this, stated with the estimate: 85%; the middle value lies on the limit itself.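

In this assay compound 4 gives > 100000 nM, which is a limit of the assay and not a number. With compound 3 also at a limit, no step can be read between compound 3 and compound 4. All the values shown stand at one limit: the limit of > 100000 nM in this assay, at which 4 of the 4 values shown sit. The compounds shown leave open whether piperidin-1-yl in place of pyrrolidin-1-yl changes antiproliferative activity at all.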